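What a Chloro Might Do to Compound 2

This account rests on a few compounds, and the source may have more. Where it says the series, first, only, none or still open, it means among the compounds named here.

Two compounds have so far been examined in a functional assay on HO8910 cells (Homo sapiens) for inhibition, read by MTT assay, with a stated time of 24 h, tested at 100 ug/mL; on this read-out lower numbers stand for less inhibition of growth and higher numbers for more inhibition of growth at the one concentration tested. Compound 1 (`O=C(CCCCC1CCSS1)Nc1ccccc1Cl`) was reported as "not active" (no number reported), and no number was given for it. Going by the values given here, compound 2 (`O=C(CCCCC(S)CCS)Nc1ccccc1`) gave 13.7%, which is the only number in this small set. It therefore stands alone, with no second value to rank it against.

The next compound to be tested is compound 3 (`O=C(CCCCC(S)CCS)Nc1ccccc1Cl`), which is compound 2 with a single change: chloro in place of hydrogen on an aromatic carbon. The chloro takes the place of a hydrogen on an aromatic carbon, ortho to a large group. Among the compounds with values here, no two measured compounds differ in one place alone, so the data contain no measured step that could guide the forecast. With nothing to favour either direction, no step beyond the usual scatter is expected in this assay. The expected change is a number 1.3 percentage points higher from compound 2 to compound 3 (within the scatter), and the wide range around it reflects how little has been measured. For compound 3 the estimated value is 15%, with an expected range from 4% to 33%.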

Compound 3, percent growth inhibition at one concentration: "not active" (no number reported)
Compound 3 has no reported number here; there is nothing to compare the estimate with.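

Going by these compounds alone, compound 3 carries no number in this assay, and no step from compound 2 to compound 3 can be read. The compounds shown leave open whether chloro in place of hydrogen changes growth inhibition at all, with compound 2 the only one holding a number. Nothing shown here offers an explanation for the result for compound 3.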